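Urea variation on a sulfonamide-bearing proline scaffold

The source may hold more compounds than are shown below. What is called first, only, known or untested is meant among the compounds shown, and "the series" means these compounds.

Compound 2 `CC(C)(C)NC(=O)N1CCC[C@H]1C(=O)N1CCC(NS(=O)(=O)c2cc(S(=O)(=O)c3ccccc3)ccc2C(F)(F)F)CC1` gives 30 nM in a functional assay on U2OS cells for antagonist activity at proto-oncogene Wnt-3 (Homo sapiens), read by a luciferase reporter, with a stated time of 18 h; on this read-out higher numbers stand for an effect only at larger amounts of compound and lower numbers for an effect already at smaller amounts. Of the two measured numbers it is the lower one: compound 1 `CC(C)(C)CC(=O)N1CCC[C@H]1C(=O)N1CCC(NS(=O)(=O)c2cc(S(=O)(=O)c3ccccc3)ccc2C(F)(F)F)CC1` gives 120 nM in this assay, and the difference is a 4.0-fold lower number from compound 1 to compound 2 (0.60 log units; beyond the scatter). Compound 3 `O=C([C@@H]1CCCN1C(=O)N1CCOCC1)N1CCC(NS(=O)(=O)c2cc(S(=O)(=O)c3ccccc3)ccc2C(F)(F)F)CC1` carries the change (morpholin-4-yl in place of (tert-butyl)amino on a carbonyl carbon). Within the data shown here, the only measured step concerns the same carbonyl carbon, where the shift from neopentyl to (tert-butyl)amino was of modest size and beyond the scatter, but that step does not show what happens when the (tert-butyl)amino group, with its single hydrogen-bond donor, is exchanged for a morpholin-4-yl ring that has no donor and one acceptor. Among the measured compounds shown here, with no direct precedent, a step of modest size toward higher numbers is expected, so that the move from compound 2 to compound 3 is estimated at a 2.0-fold higher number from compound 2 to compound 3 (0.30 log units; within the scatter). Compound 3 is therefore expected to give about 60 nM in this assay, within a range from 15 nM to 250 nM.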

Compound 3, half-maximal effective concentration: 280 nM
The estimate for compound 3 lay 4.7-fold (0.67 log units) below the measured number; measured number outside the range, above it.
By their numbers in this assay, from the lowest: compound 2; then compound 1; then compound 3.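

In this assay, the morpholin-4-yl group on this carbonyl carbon costs more than the earlier step gained, with a 9.3-fold higher number from compound 2 to compound 3 (0.97 log units; beyond the scatter) and a 2.3-fold higher number from compound 1 to compound 3 (0.37 log units; beyond the scatter), so compound 3 is the least potent of the three. Compound 3 keeps a nitrogen on the carbonyl carbon, as compound 2 does, yet its number is higher than that of compound 1 with neopentyl, so a nitrogen at this place does not by itself bring a lower number. Nothing available explains the size of either step.

The change from (tert-butyl)amino to morpholin-4-yl alters the hydrogen-bond donor count, the ring and the oxygen together, and these three compounds cannot separate them. Open-chain diethylamino, a piperidin-1-yl ring and a cyclohexylamino group would each leave only part of that change in place.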